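This account rests on a few compounds, and the source may have more. Where it says the series, first, only, none or still open, it means among the compounds named here.

Compound 2 `COc1cc(-c2nn(-c3cccc(NC(=O)c4ccc(Cl)c(C(F)(F)F)c4)c3)cc2-c2ccncc2)ccc1Cl` is the starting point. In a functional assay on U-251 cells (Homo sapiens) for inhibition, read by sulforhodamine B assay, with a stated time of 48 h (a lower number here means a stronger inhibitor of growth, a higher number a weaker inhibitor of growth), compound 2 reaches only a limit of the assay, > 32500 nM, rather than a number. Within the data shown here, the one measured comparison available is with compound 1 `COc1cc(-c2nn(-c3cccc(NC(=O)Nc4ccc(Cl)c(Cl)c4)c3)cc2-c2ccncc2)ccc1Cl`, which gives 2470 nM in this assay. That step, an at least 13-fold higher number from compound 1 to compound 2 (1.11 log units; beyond the scatter), runs towards much weaker growth inhibition, and its end point is the limit of > 32500 nM in this assay, at which 1 of the 2 values shown sits.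

Compound 3 `COc1cc(-c2nn(-c3cccc(NC(=O)Nc4ccc(Cl)c(C(F)(F)F)c4)c3)cc2-c2ccncc2)ccc1Cl` has not yet been measured. The change from compound 2 to compound 3 is (4-chloro-3-(trifluoromethyl)phenyl)amino in place of 4-chloro-3-(trifluoromethyl)phenyl on a carbonyl carbon. Compound 3 thus keeps the aryl group of compound 2 but carries the same urea-type linkage as compound 1, so the large measured step bears on it in reverse: one of the two things altered on the way to compound 2 is restored. The expected step is an at least 9.2-fold lower number from compound 2 to compound 3 (0.96 log units; beyond the scatter), towards lower numbers, though with compound 2 known only as a limit its true size is uncertain. Compound 3 is therefore estimated at 3500 nM in this assay, with a range from 900 nM to 16000 nM.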

Compound 3, concentration for total growth inhibition: 4180 nM
Compound 3: the middle estimate sits 1.2-fold (0.08 log units) below what was measured; low and high end bracket the measured number.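

With the 4-chloro-3-(trifluoromethyl)phenyl group held constant, the result isolates the linkage on the carbonyl carbon, which the earlier step could not do because the aryl group and the linkage changed together there. In this assay, adding the amino nitrogen gives an at least 7.7-fold lower number from compound 2 to compound 3 (0.89 log units; beyond the scatter), so growth inhibition within this pair depends strongly on the urea-type linkage, although compound 2 is known only as a limit of the assay, leaving the true size of this step open: the limit of > 32500 nM in this assay, at which 1 of the 3 values shown sits.

The aryl change can now also be read with the urea-type linkage in place, and it gives a 1.7-fold higher number from compound 1 to compound 3 (0.23 log units; within the scatter), so trifluoromethyl and chloro on that aromatic carbon cannot be told apart here.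

Still open, as far as these compounds go, is whether the urea-type linkage must keep its hydrogen on the added nitrogen, which a methyl group on that nitrogen, or an oxygen in its place, would test. Also open, from the compounds shown here alone, is whether the tolerance at the aromatic carbon extends to other groups, such as a nitrile or a methoxy group, in place of the trifluoromethyl.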